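Replacing the 3-methoxyphenyl of compound 1

A few compounds are considered here, and "the series" means these few. Any claim that something is new, unique, unknown or untested is made for them only; others in the source may bear on it.

In a functional assay on U-87MG ATCC cells for antiproliferative activity against U-87 MG (Homo sapiens), read by MTT assay, with a stated time of 48 h (on this read-out lower numbers stand for stronger inhibition and higher numbers for weaker inhibition), compound 1 (`COc1ccc(-c2nc(C)c(C(=O)CSc3nc(-c4cccc(OC)c4)c(C#N)c(=O)[nH]3)s2)cc1`) gives 15300 nM, the lower of the two numbers measured, and compound 2 (`COc1cccc(-c2nc(SCC(=O)c3sc(-c4ccccc4)nc3C)[nH]c(=O)c2C#N)c1`) gives 59700 nM. Compound 3 (`COc1ccc(-c2nc(C)c(C(=O)CSc3nc(-c4ccc(Cl)c(Cl)c4)c(C#N)c(=O)[nH]3)s2)cc1`) carries 3,4-dichlorophenyl in place of 3-methoxyphenyl, next to the ring nitrogen and ortho to a cyano group: 3,4-dichlorophenyl in place of 3-methoxyphenyl on an aromatic carbon. Among the compounds with values here, the only measured step, a 3.9-fold higher number from compound 1 to compound 2 (0.59 log units; beyond the scatter), leaves the 3-methoxyphenyl untouched, so it offers only an indirect guide to size and none to direction. A modest change is tentatively expected, with the estimated step being a 1.5-fold lower number from compound 1 to compound 3 (0.18 log units; within the scatter). Compound 3 is expected at 10000 nM, within an estimated range of 3500 nM to 30000 nM.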

Compound 3, half-maximal inhibitory concentration: 68500 nM
Beside the measured number, compound 3's estimate is 6.9-fold (0.84 log units) below it; the measured number lies above the stated range.
By their numbers in this assay, from the lowest: compound 1; then compounds 2 and 3 (each within the scatter of the next).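

In this assay, the position holding the 3-methoxyphenyl of compound 1 proves sensitive to its aryl group: 3,4-dichlorophenyl there gives a 4.5-fold higher number from compound 1 to compound 3 (0.65 log units; beyond the scatter), so this replacement does not improve on compound 1. Within the data shown here, this is the first measured change at this position, and its direction is toward weaker inhibition. No measured evidence accounts for the loss. Still open, going by these compounds, is whether a single chlorine or an unsubstituted phenyl would behave like either group. On these data alone, how an amine or a carboxylic acid on this aryl ring would read out also remains open.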